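This account rests on a few compounds, and the source may have more. Where it says the series, first, only, none or still open, it means among the compounds named here.

In a functional assay on PC-3 cells (Homo sapiens) for antiproliferative activity, read by sulforhodamine B assay, with a stated time of 3 days (on this read-out higher numbers stand for an effect only at larger amounts of compound and lower numbers for an effect already at smaller amounts), compound 1 `CCCC1=C(OC)C(CCC)(CCC)C(=O)/C(=C(O)\C=C\c2ccccc2)C1=O` gives 8.2 uM, compound 2 `CCCC1=C(OCCC(C)C)C(CCC)(CCC)C(=O)/C(=C(O)\C=C\c2ccccc2)C1=O` gives 17 uM, and compound 3 `CCCCOC1=C(CCC)C(=O)/C(=C(O)/C=C/c2ccccc2)C(=O)C1(CCC)CCC` gives 9.6 uM. Compound 3 thus stands second highest of the three numbers, nearest to compound 1 and furthest from compound 2, both gaps within the scatter. Compound 4 `CCCOC1=C(CCC)C(=O)/C(=C(O)/C=C/c2ccccc2)C(=O)C1(CCC)CCC` differs from compound 3 by hydrogen in place of methyl on a saturated chain carbon, three bonds along the chain from an oxygen on an unsaturated carbon. Among the compounds with values here, two measured steps bear on this: a 1.2-fold higher number from compound 1 to compound 3 (0.07 log units; within the scatter), and a 1.8-fold lower number from compound 2 to compound 3 (0.25 log units; within the scatter). Within the data shown here, the only step beyond the scatter, a 2.1-fold higher number from compound 1 to compound 2 (0.32 log units; beyond the scatter), went with a bulkier chain, not a shorter one. Trimming the chain in this way is therefore expected to give no step beyond the scatter, a 1.1-fold lower number from compound 3 to compound 4 (0.03 log units; within the scatter). Compound 4 is accordingly estimated at 9 uM, in a range from 5 uM to 17 uM.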

Compound 4, concentration for half-maximal effect: 8.6 uM
Beside the measured number, compound 4's estimate is 1.0-fold (0.02 log units) above it; the range from low to high includes it.
By their numbers in this assay, from the lowest: compounds 1, 4, 3 and 2 (each within the scatter of the next, the first and the last beyond it).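

In this assay, cutting butyl to propyl gives a 1.1-fold lower number from compound 3 to compound 4 (0.05 log units; within the scatter), and the two further steps, a 2.0-fold lower number from compound 2 to compound 4 (0.30 log units; within the scatter) and a 1.0-fold higher number from compound 1 to compound 4 (0.02 log units; within the scatter), also stay within the scatter. Within the data shown here, compound 4 adds a third chain on this oxygen, and among methyl, propyl and butyl no step lies beyond the scatter. Only compound 1 and compound 2 remain apart beyond it, so the length of these unbranched chains shows no effect here. Going by these compounds, whether a longer chain such as octyl, or an amine in place of propyl, would keep the number there stays open. Nothing shown here accounts for these numbers.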